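Replacing a methoxy with methylpiperazinyl on the shared core

The source may hold more compounds than are shown below. What is called first, only, known or untested is meant among the compounds shown, and "the series" means these compounds.

Measured compounds in an assay on isolated protein for displacement of a labelled ligand from 5-hydroxytryptamine receptor 6 (Homo sapiens), read by scintillation counting, with a stated time of 1 h; on this read-out lower numbers stand for stronger inhibition and higher numbers for weaker inhibition:
compound 1 `O=S(=O)(c1ccccc1)n1ccc2c(O)cccc21`: 108 nM
compound 2 `COc1cccc2c1ccn2S(=O)(=O)c1ccccc1`: 262 nM
compound 3 `O=S(=O)(c1ccccc1)n1cc(N2CCCCC2)c2ccccc21`: 219 nM

Compound 2 gives the highest number of the three in this assay. Its nearest neighbour is compound 3, whose value lies within the usual scatter of that of compound 2, so the two cannot be ordered. Compound 1 stands furthest from it, with a difference beyond the scatter.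

The unmeasured compound 4 `CN1CCN(c2cccc3c2ccn3S(=O)(=O)c2ccccc2)CC1` differs from compound 2 in one place: 4-methylpiperazin-1-yl in place of methoxy on an aromatic carbon. Within the data shown here, the only measured step at this position is a 2.4-fold higher number from compound 1 to compound 2 (0.38 log units; beyond the scatter), where a methyl was added to the hydroxyl oxygen; it shows that this position tolerates change without a large shift. Among the measured compounds shown here, no measured step exchanges an oxygen substituent for a nitrogen-linked ring here, so the size of the coming step can only be guessed. Compound 3 shows that a saturated nitrogen ring elsewhere on the shared core is compatible with a number of similar size.

Compound 4 is therefore expected to give a lower number than compound 2, with the step of a 4.4-fold lower number from compound 2 to compound 4 (0.64 log units; beyond the scatter) being the estimate. The estimate for compound 4 in this assay is 60 nM, within a range from 15 nM to 300 nM.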

Compound 4, inhibition constant: 1 nM
Compound 4: the middle estimate sits 60-fold (1.78 log units) above what was measured; the measured number lies below the stated range.
By their numbers in this assay, from the lowest: compound 4; then compound 1; then compounds 3 and 2 (each within the scatter of the next).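

In this assay, placing 4-methylpiperazin-1-yl on this aromatic carbon in place of methoxy gives a 260-fold lower number from compound 2 to compound 4 (2.42 log units; beyond the scatter), and placing it there in place of hydroxy gives a 110-fold lower number from compound 1 to compound 4 (2.03 log units; beyond the scatter). Among these compounds, both steps are large, whereas the only earlier step at this carbon, the exchange between the two oxygen substituents, was modest at a 2.4-fold higher number from compound 1 to compound 2 (0.38 log units; beyond the scatter). The earlier compounds therefore showed only a small shift at this carbon, while compound 4 shows that the number here can move much further with a nitrogen-linked ring in place of an oxygen substituent, although nothing available explains why the step is so large.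

The compounds shown leave open which part of the entering group accounts for the step, since it differs from methoxy and hydroxy in both its ring and its terminal N-methyl group. A piperazin-1-yl ring without the methyl, a piperidin-1-yl ring or an open-chain amine such as dimethylamino at the same carbon would begin to separate these parts, and the same 4-methylpiperazin-1-yl group on another carbon of the ring would show how far the step depends on this place.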